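This account rests on a few compounds, and the source may have more. Where it says the series, first, only, none or still open, it means among the compounds named here.

Measured compounds:
- Compound 1 `CN(O)C(=O)c1ccccn1`: > 1000000 nM, a limit of the assay
- Compound 2 `CONC(=O)c1ccccn1`: > 1000000 nM, a limit of the assay
- Compound 3 `O=C(NO)c1ccc[n+]([O-])c1`: > 1000000 nM, a limit of the assay

In an ADME assay on Huh-7 cells (Homo sapiens) for cytotoxicity, read by MTT assay, with a stated time of 72 h (on this read-out higher numbers stand for lower toxicity in this test and lower numbers for higher toxicity in this test), compound 1 gives > 1000000 nM, which is a limit rather than a measured number. Compound 2 gives > 1000000 nM in this assay, again a limit. Compound 3 gives > 1000000 nM in this assay, once more a limit. Compound 2 therefore stands where every measured compound stands: the limit of > 1000000 nM in this assay, at which 3 of the 3 values shown sit. For the measured compounds named here, the one step between compounds that differ in a single place, a step that the two limits leave unreadable from compound 1 to compound 2, cannot be read, since both of its ends are limits.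

Compound 4 `O=C(NO)c1ccccn1` differs from compound 2 in one place: hydrogen in place of methyl on an oxygen. Going by the values given here, no measured step bears directly on this change, and the only step that exists is unreadable, so there is nothing from which a movement in either direction could be drawn. The expectation for compound 4 is therefore a value at the same limit, that is, a step that the limit leaves unreadable from compound 2 to compound 4 that is not expected to show beyond the scatter. Compound 4 is estimated at 1500000 nM in this assay, with a range from 600000 nM to 4000000 nM.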

Compound 4, half-maximal cytotoxic concentration: 710000 nM
Compound 4: middle estimate off by 2.1-fold (0.32 log units), on the high side; the range from low to high includes it.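

In this assay, for the compounds shown here, compound 4 gives 710000 nM, the first number in this set that is not a limit, so the change can now be given a minimum size in each of two places: hydrogen in place of methyl on an oxygen gives an at least 1.4-fold lower number from compound 2 to compound 4 (0.14 log units; that floor lies within the scatter), and the same exchange made on an amide-type nitrogen gives an at least 1.4-fold lower number from compound 1 to compound 4 (0.14 log units; that floor lies within the scatter). Each step is only a floor, since one of its ends is a limit, and so neither one shows a real difference in toxicity in this test, though a larger gap remains possible. Compound 2 still stands at a limit, as does compound 1, and the wider picture stays much as it was: the limit of > 1000000 nM in this assay, at which 3 of the 4 values shown sit.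

What the compounds shown leave open is the true size of both steps, and so whether either methyl matters at all in this test. Also open, on these data alone, is how the number would respond to a longer chain such as ethyl on that oxygen, or to an amine or a carboxylic acid in place of the hydroxyamino group on the carbonyl.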